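Bromo for methoxy: what liver-cell tolerance may do

A few compounds are considered here, and "the series" means these few. Any claim that something is new, unique, unknown or untested is made for them only; others in the source may bear on it.

Measured compounds:
compound 1 `COc1ccc(-n2cc(CNCCN3CCN(C)CC3)c(-c3ccccc3C)n2)cc1` — > 20000 nM
compound 2 `CCCN1CCC(CNCc2cn(-c3ccc([N+](=O)[O-])cc3)nc2-c2ccc(OC(F)(F)F)cc2)CC1` — 18000 nM

Two compounds have so far been run in an ADME assay on Huh-7 cells (Homo sapiens) for cytotoxicity; a higher number here means that more compound is tolerated, a lower number that less compound is tolerated. For compound 1 the reported value of > 20000 nM is a limit of the assay, not a number, namely (the limit of > 20000 nM in this assay, at which 1 of the 2 values shown sits). Compound 2 gives 18000 nM in this assay. The two differ from each other in many places at once, so their values show only that both sit near the upper reach of what this assay reports.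

Compound 3 `Cc1ccccc1-c1nn(-c2ccc(Br)cc2)cc1CNCCN1CCN(C)CC1` has not yet been tested. It differs from compound 1 in a single place: bromo in place of methoxy on an aromatic carbon. Among the measured compounds shown here, no step between measured compounds covers this change, and compound 1 itself stands at a limit, so the direction cannot be read from anything measured here. The account expects a step no larger than the usual scatter, in either direction or none at all. Compound 3 is therefore estimated at 18000 nM, with a range from 7000 nM to 40000 nM. That estimate implies an expected step of an at least 1.1-fold lower number from compound 1 to compound 3 (0.04 log units; that floor lies within the scatter), within the scatter.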

Compound 3, half-maximal cytotoxic concentration: 9600 nM
Estimate against measurement, compound 3: 1.9-fold (0.27 log units) above; low and high end bracket the measured number.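

The change from 4-methoxyphenyl to 4-bromophenyl gives, in this assay, an at least 2.0-fold lower number from compound 1 to compound 3 (0.31 log units; beyond the scatter). Among the compounds shown here, this is the first comparison here between compounds that differ in one place, and it shows that this aromatic carbon, para to a large group, is not indifferent to what it carries: with the rest of the molecule unchanged, less compound is tolerated with bromo than with methoxy. The full size of the step remains unknown because compound 1 stands at a limit of the assay rather than at a number: the limit of > 20000 nM in this assay, at which 1 of the 3 values shown sits.

On these data alone, how chloro, trifluoromethyl or a plain hydrogen on this carbon would compare with bromo and methoxy remains open, so these compounds cannot say whether the step reflects the arrival of bromo, the departure of methoxy or both. As far as these compounds go, it is also open whether the same exchange would give a similar step if another amine took the place of the one on the side chain of compound 1.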